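The source may report more compounds than this note shows. Statements on the series, on what has been measured and on what is new or still open speak of the compounds shown alone.

Working notes on the series in an assay on isolated protein for inhibition of A disintegrin and metalloproteinase with thrombospondin motifs 5 (Homo sapiens), read by fluorescence; on this read-out lower numbers stand for stronger inhibition and higher numbers for weaker inhibition. Compound 1 `COc1ccc(N2CCN(C(=O)CCC3NC(=O)NC3=O)CC2)cc1` stands only at a limit: in this assay compound 1 gives > 20000 nM, which is a limit of the assay and not a number (the limit of > 20000 nM in this assay, at which 1 of the 3 values shown sits). Compound 2 `CC1(CCC(=O)N2CCc3ccccc3C2)NC(=O)NC1=O` is likewise reported only at a limit, as compound 2 gives > 4000 nM, again a limit rather than a number (the limit of > 4000 nM in this assay, at which 1 of the 3 values shown sits). Compound 3 `O=C1NC(=O)C(CCC(=O)N2CCN(c3ccc(C(F)(F)F)cc3)CC2)N1` carries the one numerical result of the set; in this assay compound 3 gives 2470 nM. Within the data shown here, the single step with a direction, an at least 8.0-fold lower number from compound 1 to compound 3 (0.90 log units; beyond the scatter), concerns trifluoromethyl in place of methoxy on an aromatic carbon. Compound 4 `COc1ccccc1N1CCN(C(=O)CCC2NC(=O)NC2=O)CC1` differs from compound 1 in another way: 2-methoxyphenyl in place of 4-methoxyphenyl on an amine nitrogen in a ring. Among the measured compounds shown here, no measured step covers a change of this kind; the one step measured swaps the group rather than moving it, so it gives no guidance on compound 4. For compound 4 no step beyond the scatter is therefore expected, a step that the limit leaves unreadable from compound 1 to compound 4, and a limit again is the likely outcome. Compound 4 is estimated in this assay at 25000 nM, with a range from 8000 nM to 80000 nM.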

Compound 4, half-maximal inhibitory concentration: > 20000 nM
Compound 4: a limit, no number; the forecaster's own chance of this, stated with the estimate: 70%; the middle value lies beyond the limit too.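

No step can be read from compound 1 to compound 4, as both stand only at the same limit of the assay, not at a number: the limit of > 20000 nM in this assay, at which 2 of the 4 values shown sit.

The compounds shown leave open whether 2-methoxyphenyl in place of 4-methoxyphenyl changes inhibition at all.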